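The source may hold more compounds than are shown below. What is called first, only, known or untested is meant among the compounds shown, and "the series" means these compounds.

Compound 1 `COc1ccc(C(=O)/C(=C/c2ccccc2F)COC(C)=O)cc1` — 8200 nM
Compound 2 `COc1ccc(C(=O)/C(=C/c2ccccc2Cl)COC(=O)c2ccccc2)cc1` — 7000 nM
Compound 3 `COc1ccc(C(=O)/C(=C/c2ccccc2F)CCOC(C)=O)cc1` — > 100000 nM

In a functional assay on NB-4 cells (Homo sapiens) for inhibition, read by XTT assay, with a stated time of 48 h (on this read-out higher numbers stand for weaker inhibition and lower numbers for stronger inhibition), compound 1 gives 8200 nM and compound 2 gives 7000 nM, two numbers that lie close to each other. For compound 3 this assay reports only a limit, > 100000 nM. Within the data shown here, the single step measured between compounds that differ in one place is an at least 12-fold higher number from compound 1 to compound 3 (1.08 log units; beyond the scatter), and it leaves compound 3 standing at the limit of > 100000 nM in this assay, at which 1 of the 3 values shown sits, so no number is available for it.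

Compound 4 `COc1ccc(C(=O)/C(=C/C2CCCCC2)CCOC(C)=O)cc1` differs from compound 3 by cyclohexyl in place of 2-fluorophenyl on a double-bonded chain carbon bound to a double-bonded chain carbon. Among the measured compounds shown here, none of the measured steps touches this position; the only measured step concerns the chain on the saturated carbon, which compound 4 keeps unchanged from compound 3. For the measured compounds named here, since compound 3 already sits at the limit of this assay and the change in compound 4 has no measured counterpart here, the step that the limit leaves unreadable from compound 3 to compound 4 is expected to show nothing beyond the scatter, and compound 4 is expected to remain at or beyond the limit as well. Compound 4 is therefore estimated at 150000 nM, with a range from 40000 nM to 600000 nM.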

Compound 4, half-maximal inhibitory concentration: > 100000 nM
Compound 4: only a limit was reported; the forecaster's own chance of this, stated with the estimate: 80%; the middle value lies beyond the limit too.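

In this assay compound 4 gives > 100000 nM as a limit and not a number. Compound 3 also stands at a limit, so no step can be read from compound 3 to compound 4: the limit of > 100000 nM in this assay, at which 2 of the 4 values shown sit.

The compounds shown leave open how cyclohexyl and 2-fluorophenyl compare on a double-bonded chain carbon bound to a double-bonded chain carbon.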